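Chain extension on the acetoxy group of compound 3

The compounds below may be only part of what the source reports. "The series", "measured", "known", "first", "only" and "open" are said of these compounds alone.

Compound 1 `CCc1cccc2c(OC)c(-c3occ(C)c3CO)ccc12` carries a free hydroxyl on a saturated carbon; in a functional assay on KB cells (Homo sapiens) for cytotoxicity, read by MTT assay, with a stated time of 72 h (a higher number here means that more compound is needed for the effect, a lower number that less compound is needed), compound 1 gives 7.1 ug/mL. Compound 2 `CCc1cccc2c(OC)c(-c3occ(C)c3COC)ccc12` has methyl in place of that hydrogen. In this assay compound 2 reaches only the assay limit of > 10 ug/mL. Compound 3 `CCc1cccc2c(OC)c(-c3occ(C)c3COC(C)=O)ccc12` has acetyl in place of that hydrogen. Compound 3 likewise gives only the assay limit of > 10 ug/mL. Thus an at least 1.4-fold higher number from compound 1 to compound 2 (0.14 log units; that floor lies within the scatter) and an at least 1.4-fold higher number from compound 1 to compound 3 (0.14 log units; that floor lies within the scatter), while a step that the two limits leave unreadable from compound 2 to compound 3. Compound 3 therefore stands at the limit of > 10 ug/mL in this assay, at which 2 of the 3 values shown sit.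

Compound 4 `CCc1cccc2c(OC)c(-c3occ(C)c3COC(=O)CCN(CC)CC)ccc12` differs from compound 3 by (diethylamino)methyl in place of hydrogen on a saturated chain carbon bound to a carbonyl carbon. The measured steps that bear on this position are the two from compound 1 to the capped compounds, each a rise of at least a small size, and the unreadable step between the two capped compounds. The expectation for compound 4 is accordingly a number at or near the limit, with a step that the limit leaves unreadable from compound 3 to compound 4 expected to stay within the scatter. The estimate for compound 4 is 12 ug/mL, with a range from 5 ug/mL to 30 ug/mL.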

Compound 4, concentration for half-maximal effect: > 10 ug/mL
Compound 4: only a limit was reported; the forecaster's own chance of this, stated with the estimate: 60%; the middle value does not contradict the limit.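

Compound 4 is a third capped compound that gives only a limit in this assay, so adding (diethylamino)methyl on a saturated chain carbon bound to a carbonyl carbon yields no readable value. Against the free hydroxyl of compound 1, the change amounts to an at least 1.4-fold higher number from compound 1 to compound 4 (0.14 log units; that floor lies within the scatter), and the steps from compound 2 and compound 3 to compound 4 cannot be read. A tertiary amine on the acyl chain therefore joins methyl and acetyl at the same ceiling: the limit of > 10 ug/mL in this assay, at which 3 of the 4 values shown sit.

Going by these compounds, how far the capped compounds actually lie from compound 1, and whether they differ from one another, remains open. Also open, on these data alone, is how this position responds to a carboxylic acid in place of the diethylamino group, or to a morpholine ring or a longer chain on the acyl group.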